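The compounds below may be only part of what the source reports. "The series", "measured", "known", "first", "only" and "open" are said of these compounds alone.

In a functional assay on CCRF-CEM cells (Homo sapiens) for inhibition (on this read-out lower numbers stand for stronger inhibition and higher numbers for weaker inhibition), compound 1 (`C#CCN(Cc1ccc2nc(C)nc(O)c2c1)c1cccc(C(F)(F)F)c1`) gives > 4300 nM as a limit, not a number. Compound 2 (`C#CCN(Cc1ccc2nc(C)nc(O)c2c1)c1cccc(Br)c1`) gives 5700 nM in the same test. Among the compounds with values here, the only measured step is a step that the limit leaves unreadable from compound 1 to compound 2 and it concerns a different group, so it offers no size to carry over. Compound 3 (`C#CCN(Cc1ccc2nc(C)nc(S)c2c1)c1cccc(C(F)(F)F)c1`) has sulfanyl in place of hydroxy on an aromatic carbon. Within the data shown here, no measured step touches this group, so no change beyond the scatter is expected, and the estimated step is a step that the limit leaves unreadable from compound 1 to compound 3 on that basis. Compound 3 is expected near 6000 nM with an estimated range of 2500 nM to 15000 nM in this assay here.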

Compound 3, half-maximal inhibitory concentration: > 5600 nM
Compound 3: a limit, no number; the forecaster's own chance of this, stated with the estimate: 40%; the middle value is on the limit's open side.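

Compound 1 and compound 3 both give limits, not numbers, and the step between them cannot be read. Whether sulfanyl in place of hydroxy changes inhibition at all, and by how much, stays open among the compounds shown.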